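From 4-Methoxyphenyl to Phenethyl on the Sulfur Chain

The compounds below may be only part of what the source reports. "The series", "measured", "known", "first", "only" and "open" are said of these compounds alone.

In a functional assay on HGC-27 cells (Homo sapiens) for inhibition, read by MTT assay, with a stated time of 72 h (a lower number here means a stronger inhibitor, a higher number a weaker inhibitor), compound 1 `Cc1cc(N2CC[C@@H](C)[C@@H](N(C)c3ncnc4[nH]ccc34)C2)n2nc(SCc3csc4ccc(Cl)cc34)nc2n1` reads > 100000 nM, which is a limit of the assay. Among the compounds with values here, compound 2 `COc1ccc(CSc2nc3nc(C)cc(N4CC[C@@H](C)[C@@H](N(C)c5ncnc6[nH]ccc56)C4)n3n2)cc1` gives 18200 nM, the only actual number so far. Compound 3 `Cc1cc(N2CC[C@@H](C)[C@@H](N(C)c3ncnc4[nH]ccc34)C2)n2nc(SCCCc3ccccc3)nc2n1` keeps the shared core and carries phenethyl in place of 4-methoxyphenyl on a saturated chain carbon bound to a sulfur. Within the data shown here, the one measured step at that place, an at least 5.4-fold lower number from compound 1 to compound 2 (0.73 log units; beyond the scatter), involved a different group and gives only a bound, so it offers little guidance on direction. A change within the scatter is expected, estimated as a 1.4-fold higher number from compound 2 to compound 3 (0.14 log units; within the scatter). Compound 3 is expected at 25000 nM, with an estimated range of 7000 nM to 90000 nM.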

Compound 3, half-maximal inhibitory concentration: > 100000 nM
Compound 3 ended at the assay's limit; the forecaster's own chance of this, stated with the estimate: 20%; middle value at least 4.0-fold (0.60 log units) from the limit.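

The change to phenethyl on a saturated chain carbon bound to a sulfur gives an at least 5.4-fold higher number from compound 2 to compound 3 (0.73 log units; beyond the scatter), so this place responds even when the aromatic ring and the heavy-atom count stay the same. Compound 3 reads as a limit, and the step from compound 1 to compound 3 cannot be read. Only compound 2 has an actual number in this assay, and the other two share one limit: the limit of > 100000 nM in this assay, at which 2 of the 3 values shown sit.

The compounds shown do not separate the methoxy group from the chain that carries the ring. Going by these compounds, how a plain benzyl, a 4-hydroxybenzyl or a 4-aminobenzyl group would read on that sulfur remains open.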